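The source may hold more compounds than are shown below. What is called first, only, known or untested is meant among the compounds shown, and "the series" means these compounds.

Measured compounds in a functional assay on MCF7 cells (Homo sapiens) for inhibition, read by MTT assay, with a stated time of 24 h; a lower number here means a stronger inhibitor, a higher number a weaker inhibitor:
- compound 1 `CCOC(=O)C1=Cc2ccccc2OC1(OCc1cn(CC(=O)Nc2ccc(C)cc2)nn1)C(F)(F)F` gives > 150000 nM
- compound 2 `CCOC(=O)C1=Cc2ccccc2OC1(OCc1cc(-c2ccc3ccccc3c2)no1)C(F)(F)F` gives 65400 nM
- compound 3 `COc1ccc(-c2cc(COC3(C(F)(F)F)Oc4ccccc4C=C3C(=O)O)on2)cc1` gives 35200 nM

Compound 1 stands at the limit of > 150000 nM in this assay, at which 1 of the 3 values shown sits. That entry is a limit of the assay and not a measured number: the cells were not inhibited within the tested range, so only a bound is known. Compound 2, in this assay, gives 65400 nM. Compound 3, in this assay, gives 35200 nM. The two numbers for compound 2 and compound 3 lie close to each other, and both compounds carry a different side group than compound 1, so they do not show what a single change at the amide-type nitrogen does.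

Compound 4 `CCOC(=O)C1=Cc2ccccc2OC1(OCc1cn(CC(=O)Nc2cccc(Cl)c2)nn1)C(F)(F)F` has not yet been measured. It differs from compound 1 in one place:

3-chlorophenyl in place of 4-methylphenyl on an amide-type nitrogen

For the measured compounds named here, no pair of measured compounds differs in just one place, so the size of this step has no measured guide. The step of a number no higher from compound 1 to compound 4 (the limit leaves the size open) is expected to be none beyond the scatter. Compound 4 is therefore estimated at 150000 nM, within a range from 50000 nM to 450000 nM, and the assay may again report only a limit.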

Compound 4, half-maximal inhibitory concentration: 11600 nM
For compound 4 the middle estimate is 13-fold (1.11 log units) above the measured one, and the stated range ends above it.
By their numbers in this assay, from the lowest: compound 4; then compounds 3 and 2 (each within the scatter of the next). At a limit, above all of these: compound 1.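

In this assay compound 1 gives > 150000 nM, which is a limit of the assay and not a number. Replacing 4-methylphenyl with 3-chlorophenyl on the amide-type nitrogen gives an at least 12-fold lower number from compound 1 to compound 4 (1.11 log units; beyond the scatter), so the group at this position can decide whether a measurable value appears at all. The full size of this step remains unknown, since one end of it rests on a limit: the limit of > 150000 nM in this assay, at which 1 of the 4 values shown sits.

This single swap both removes the methyl group and adds the chlorine, and the compounds shown include neither a 4-chlorophenyl nor a 3-methylphenyl group that could separate these two changes. Going by these compounds, an unsubstituted phenyl group at the same nitrogen would be the plainest reference, and how it compares with compound 4 remains open.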